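The source may hold more compounds than are shown below. What is called first, only, known or untested is meant among the compounds shown, and "the series" means these compounds.

Working notes on the antiproliferative series.

Two compounds carry numbers in a functional assay on Hep 3B2 cells (Homo sapiens) for antiproliferative activity, read by MTT assay, with a stated time of 24 h, tested at 33.33 ug/mL; on this read-out higher numbers stand for a stronger effect at the one concentration tested and lower numbers for a weaker effect. Compound 1, `Cc1c(C(=O)Nc2c(F)cc(-c3cccc(F)c3)cc2F)nc2ccc(OC(F)(F)F)cc2c1O`, gives 41.3%. Compound 2, `COc1ccc2nc(C(=O)Nc3ccc(-c4ccccc4)cc3)c(C)c(O)c2c1`, gives 48.4%. The two values sit within the usual scatter of each other, so nothing can be said about which of the pair acts more strongly at the concentration tested; compound 2 simply holds the larger of the two numbers, and compound 1 lies close to it.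

Compound 3, `Cc1c(C(=O)Nc2ccc(-c3ccccc3)cc2)nc2ccccc2c1O`, has not been measured in this assay. It differs from compound 2 in one place: hydrogen in place of methoxy on an aromatic carbon. Among the measured compounds shown here, no pair of measured compounds differs in exactly this way, so there is no direct step to lean on; the only guide is the level that compound 2 shows in this assay and the size of scatter a single-concentration read-out of this kind carries.

The expectation is a step from compound 2 to compound 3 of a number 5.4 percentage points lower from compound 2 to compound 3 (within the scatter), that is, no change that would stand out beyond the scatter. Compound 3 is therefore estimated at 43%, with a range from 25% to 60%.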

Compound 3, a percentage reported as inhibition, at one concentration (the size of the read-out at that concentration, not a potency): 46.2%
Compound 3: middle estimate off by 3.2 percentage points, on the low side, within the range that was stated.
By their numbers in this assay, from the lowest: compounds 1, 3 and 2 (each within the scatter of the next).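

Working from the one step now available, hydrogen in place of methoxy on this aromatic carbon, which is meta to a fused ring and para to a fused ring, gives in this assay a number 2.2 percentage points lower from compound 2 to compound 3 (within the scatter). Among the compounds shown here, this is the first direct reading of any single change, and it shows that at this position the methoxy group can be absent without a difference that stands out from the scatter at the one concentration tested. No measurement in hand bears on why this change leaves the read-out within the scatter.

Going by these compounds, with only hydrogen and methoxy compared at this place, it stays open whether an amine, a carboxylic acid or a longer alkoxy chain on the same carbon would give a step beyond the scatter. On these data alone, because the read-out reports the size of the effect at a single concentration rather than a potency, it also stays open whether a full concentration series would separate compound 2 from compound 3.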